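The source may report more compounds than this note shows. Statements on the series, on what has been measured and on what is new or still open speak of the compounds shown alone.

Measured so far:
- compound 1 `Cc1cc(Nc2cc(-c3ccccc3)[nH]n2)n2nc(SCc3ccccc3Br)nc2n1`: 41100 nM
- compound 2 `Cc1cc(Nc2ccn(Cc3csc4ccc(Cl)cc34)n2)n2nc(SCc3ccc(Br)cc3)nc2n1`: 31400 nM

In an ADME assay on GES1 cells (Homo sapiens) for inhibition, read by MTT assay, with a stated time of 72 h (a higher number here means a weaker inhibitor, a lower number a stronger inhibitor), compound 1 gives 41100 nM and compound 2 gives 31400 nM; the two numbers lie within the scatter of each other, so nothing separates them. Compound 3 `CCCSc1nc2nc(C)cc(Nc3cc(-c4ccccc4)[nH]n3)n2n1` differs from compound 1 by ethyl in place of 2-bromophenyl on a saturated chain carbon bound to a sulfur. Among the measured compounds shown here, no measured pair shows this kind of change, so its effect is unknown. The expected step from compound 1 to compound 3 in this assay is a 1.5-fold higher number from compound 1 to compound 3 (0.16 log units; within the scatter), a modest move toward a higher number. Compound 3 is thus estimated at 60000 nM, with a range of 20000 nM to 150000 nM.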

Compound 3, half-maximal inhibitory concentration: > 50000 nM
Compound 3 gave a limit, no number; the forecaster's own chance of this, stated with the estimate: 30%; the middle value does not contradict the limit.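

In this assay, compound 3 gives a limit and not a number: > 50000 nM. At this position, on a saturated chain carbon bound to a sulfur, ethyl in place of 2-bromophenyl removes the ring and gives an at least 1.2-fold higher number from compound 1 to compound 3 (0.08 log units; that floor lies within the scatter), so the 2-bromophenyl ring is not needed to keep the number this high. Only a floor can be read for this change, and its true size stays unknown: the limit of > 50000 nM in this assay, at which 1 of the 3 values shown sits.

Open, on these data alone, is whether an amine, a carboxylic acid or a longer chain at this place would give a lower number.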